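Two Chlorines on the Sulfonyl Aryl: What to Expect

A few compounds are considered here, and "the series" means these few. Any claim that something is new, unique, unknown or untested is made for them only; others in the source may bear on it.

Compound 1 `CC1CCN(c2c(S(=O)(=O)c3ccc(Cl)cc3)cnc3cc(Cl)ccc23)CC1` is the reference point here. In an assay on isolated protein for displacement of a labelled ligand from metabotropic glutamate receptor 5 (Homo sapiens), with a stated time of 60 min, tested at 1 uM (a higher number here means more inhibition at the concentration tested (going by the name of the read-out), a lower number less inhibition), compound 1 gives 91%. Compound 3 `CC1CCN(c2c(S(=O)(=O)c3ccc(Cl)cc3)cnc3cc(F)ccc23)CC1` gives 90%, and the step of a number 1 percentage points lower from compound 1 to compound 3 (within the scatter) shows that swapping one halogen on the shared core leaves the read-out essentially unchanged. Compound 2 `Cc1ccc(S(=O)(=O)c2cnc3ccc(Cl)cc3c2N2CCC(C)CC2)cc1C` gives 84%. Compound 1 thus has the highest of the three numbers, but both other compounds sit within the usual scatter of it, so no real order can be claimed among them.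

Compound 4 `CC1CCN(c2c(S(=O)(=O)c3cc(Cl)cc(Cl)c3)cnc3cc(Cl)ccc23)CC1` is the next compound in this line. It differs from compound 1 in one place: 3,5-dichlorophenyl in place of 4-chlorophenyl on a sulfonyl sulfur. For the measured compounds named here, no measured step touches the group on the sulfonyl sulfur, so the only guide is the general steadiness of the series: the single measured step, from compound 1 to compound 3, stayed within the scatter. The change in compound 4 is therefore expected to give a step of a number 3 percentage points lower from compound 1 to compound 4 (within the scatter), that is, nothing beyond the scatter. Compound 4 is estimated to give 88% in this assay, with a range from 74% to 96%.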

Compound 4, a percentage reported as inhibition, at one concentration (the size of the read-out at that concentration, not a potency): 93%
Beside the measured number, compound 4's estimate is 5 percentage points below it; the measured number falls inside the stated range.
By their numbers in this assay, from the lowest: compounds 2, 3, 1 and 4 (each within the scatter of the next).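

At the sulfonyl sulfur, placing 3,5-dichlorophenyl where 4-chlorophenyl stood gives, in this assay, a number 2 percentage points higher from compound 1 to compound 4 (within the scatter). For the compounds shown here, this is the first measured step at this position, since the earlier step touched only a halogen on the shared core, and it shows that this position accepts an aryl group with an added chlorine without any difference that this read-out can separate from the scatter. Nothing measured here accounts for this result.

On these data alone, whether this position would also accept an aryl group carrying an amine or a carboxylic acid remains open. As far as these compounds go, because the read-out comes from one concentration and is not a potency, it also remains open whether compound 1 and compound 4 would separate at lower concentrations.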